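Methyl in place of dimethylamino on the carbonyl

The compounds below may be only part of what the source reports. "The series", "measured", "known", "first", "only" and "open" are said of these compounds alone.

Three compounds sharing one core have been run in an ADME assay on Caco-2 cells (Homo sapiens) for permeability, read by LC-MS, with a stated time of 2 h, tested at 3 uM; a higher number here means that the compound crosses the layer faster, a lower number that the compound crosses the layer more slowly. Compound 1 `CCN(c1cc2oc(-c3ccc(F)cc3)c(C(=O)NC)c2cc1-c1cc(F)c(OC)c(C(=O)NC2(c3ncccn3)CC2)c1)S(C)(=O)=O` gives 406 nm/s. Compound 2 `CCN(C(=O)OC)c1cc2oc(-c3ccc(F)cc3)c(C(=O)NC)c2cc1-c1ccc(OC)c(C(=O)NC2(c3ncccn3)CC2)c1` gives 232 nm/s, and compound 3 `CCN(C(=O)N(C)C)c1cc2oc(-c3ccc(F)cc3)c(C(=O)NC)c2cc1-c1ccc(OC)c(C(=O)NC2(c3ncccn3)CC2)c1` gives 479 nm/s. The number for compound 3 lies beyond the scatter from compound 2, while compound 1 and compound 3 sit within the scatter of each other, so nothing separates those two.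

For the measured compounds named here, one measured step concerns the same carbonyl carbon as the change considered here: a 2.1-fold higher number from compound 2 to compound 3 (0.31 log units; beyond the scatter), a dimethylamino in place of methoxy on a carbonyl carbon.

Compound 4 `CCN(C(C)=O)c1cc2oc(-c3ccc(F)cc3)c(C(=O)NC)c2cc1-c1ccc(OC)c(C(=O)NC2(c3ncccn3)CC2)c1` has not yet been measured in this assay. It differs from compound 3 in one place: methyl in place of dimethylamino on a carbonyl carbon. Going by the values given here, no measured pair sets methyl against dimethylamino or against methoxy at this carbonyl, so the one bearing step only fixes the scale: the dimethylamino-for-methoxy swap gave a modest shift, just beyond the scatter. A change of comparable size at the same carbonyl is therefore expected to leave the number near that of compound 3, within or barely beyond the scatter. For compound 4 the expected step is a 1.3-fold lower number from compound 3 to compound 4 (0.10 log units; within the scatter). Compound 4 is accordingly estimated at 380 nm/s, with a range from 200 nm/s to 700 nm/s.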

Compound 4, apparent permeability: 308 nm/s
Compound 4: middle estimate off by 1.2-fold (0.09 log units), on the high side; measured number inside the range.
By their numbers in this assay, from the lowest: compounds 2, 4, 1 and 3 (each within the scatter of the next, the first and the last beyond it).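

In this assay compound 4 places a third group on this carbonyl carbon, and its steps to the other two, a 1.6-fold lower number from compound 3 to compound 4 (0.19 log units; within the scatter) and a 1.3-fold higher number from compound 2 to compound 4 (0.12 log units; within the scatter), both stay within the scatter. The earlier step, a 2.1-fold higher number from compound 2 to compound 3 (0.31 log units; beyond the scatter), lay just beyond the scatter, but methyl now cannot be told apart from either dimethylamino or methoxy at this position, so the three groups do not fall into separate levels. Nothing among the data offered here accounts for these numbers.

The compounds shown leave open whether a larger group on this carbonyl carbon, such as a propyl chain or a cyclic amine like morpholine, would move the number beyond the scatter from compound 4. Also open, from the compounds shown here alone, is whether these carbonyl groups would keep the same narrow spread with a methyl or a cyclopropyl in place of the ethyl on the amide-type nitrogen.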